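Swapping the pyrimidine attachment point in a purine series

The source may report more compounds than this note shows. Statements on the series, on what has been measured and on what is new or still open speak of the compounds shown alone.

Four close relatives of one purine core are considered here. For compound 1 `CC(C)n1cnc2c(Nc3cccc(-c4cncnc4)c3)nc(Cl)nc21` the result in an assay on isolated protein (Asteroidea) for inhibition of G2/mitotic-specific cyclin-B (Asterina pectinifera), read by scintillation counting and 33P incorporation, with a stated time of 30 min (on this read-out higher numbers stand for weaker inhibition and lower numbers for stronger inhibition), is "not determined" (no result reported); for compound 3 `CC(C)C(O)Nc1nc(Nc2cccc(-c3ncccn3)c2)c2ncn(C(C)C)c2n1` the result in this assay is "not determined" (no result reported). Among the compounds with values here, compound 2 `CCC[C@@H](O)Nc1nc(Nc2cccc(-c3ncccn3)c2)c2ncn(C(C)C)c2n1` is therefore the only entry with a number: in this assay compound 2 gives 300 nM, and it stands alone on that footing. Compound 4 `CCC[C@@H](O)Nc1nc(Nc2cccc(-c3cncnc3)c2)c2ncn(C(C)C)c2n1`, not yet measured, differs from compound 2 only in the change (pyrimidin-5-yl in place of pyrimidin-2-yl on an aromatic carbon). Within the data shown here, no measured pair illustrates this exchange, so the direction of the step is open. Compound 4 is expected to keep a value close to that of compound 2, the step from a 1.5-fold lower number from compound 2 to compound 4 (0.18 log units; within the scatter) staying within the usual scatter. On this basis compound 4 is estimated at 200 nM, with a range from 60 nM to 700 nM.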

Compound 4, half-maximal inhibitory concentration: 130 nM
The estimate for compound 4 lay 1.5-fold (0.19 log units) above the measured number; the measured number falls inside the stated range.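

Pyrimidin-5-yl in place of pyrimidin-2-yl on this aromatic carbon gives the first readable step in this assay: a 2.3-fold lower number from compound 2 to compound 4 (0.36 log units; beyond the scatter). It shows that, with the same atoms in the entering and leaving groups, the way the ring is joined to the rest of the molecule is enough to shift the number. No measurement shown accounts for this shift.

On these data alone, what a pyridin-3-yl, a pyrimidin-4-yl or a plain phenyl group would do at this place remains open. So does whether the step would hold with a different chain on the shared core, such as a simple amine.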